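Moving a Chlorine on the Aryl Ring of Compound 2

A few compounds are considered here, and "the series" means these few. Any claim that something is new, unique, unknown or untested is made for them only; others in the source may bear on it.

For the measured compounds named here, compound 2 `CC(C)(C)C1=NN(c2ccc(Cl)cc2Cl)C(c2ccc(O)cc2)C1` gives the lower of the two numbers measured so far. In an assay on isolated protein for inhibition of protein kinase C zeta type (Homo sapiens), with a stated time of 4 min, tested at 62.5 uM (on this read-out lower numbers stand for less inhibition and higher numbers for more inhibition at the one concentration tested (going by the name of the read-out)), compound 2 gives 71%, whereas compound 1 `CC(C)(C)C1=NN(c2ccc(Br)cc2)C(c2ccc(O)cc2)C1` gives 93.2%. Going by the values given here, the single measured step, a number 22.2 percentage points lower from compound 1 to compound 2 (beyond the scatter), puts 2,4-dichlorophenyl in place of 4-bromophenyl on an amine nitrogen in a ring. Compound 3 `CC(C)(C)C1=NN(c2c(Cl)cccc2Cl)C(c2ccc(O)cc2)C1` keeps the same atoms as compound 2 but joins them differently: 2,6-dichlorophenyl in place of 2,4-dichlorophenyl on an amine nitrogen in a ring. Among the compounds with values here, no measured step rearranges the chlorines on this dichlorophenyl group, so the step from compound 1 to compound 2 bears only loosely on the present change and offers no direction for it. For compound 3 the expected step is a number 6 percentage points lower from compound 2 to compound 3 (within the scatter), a small downward drift that stays within the usual scatter. Compound 3 is accordingly expected to give about 65%, somewhere between 40% and 88%.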

Compound 3, a percentage reported as inhibition, at one concentration (the size of the read-out at that concentration, not a potency): 65.5%
For compound 3 the middle estimate is 0.5 percentage points below the measured one; low and high end bracket the measured number.
By their numbers in this assay, from the lowest: compounds 3 and 2 (each within the scatter of the next); then compound 1.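

In this assay, 2,6-dichlorophenyl in place of 2,4-dichlorophenyl on an amine nitrogen in a ring gives a number 5.5 percentage points lower from compound 2 to compound 3 (within the scatter), so at this one concentration the read-out does not separate these two arrangements of the same atoms. With 2,6-dichlorophenyl in place of 4-bromophenyl, the result is a number 27.7 percentage points lower from compound 1 to compound 3 (beyond the scatter), which shows that the gap to compound 1 holds for a second dichlorophenyl group and not only for the 2,4-dichlorophenyl group of compound 2. No measured information on the compounds explains either step.

The compounds shown leave open whether the gap goes with the bromine of compound 1 or with the second chlorine, a question that a 4-chlorophenyl group at this position would address. On these data alone, how a group of a different kind, such as 4-methoxyphenyl or 4-aminophenyl, would read here also remains open.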